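The compounds below may be only part of what the source reports. "The series", "measured", "known", "first", "only" and "open" are said of these compounds alone.

Measured so far:
compound 1 `Cc1nc2c(OCc3ccccc3)cccn2c1NCc1ccccc1`, 0%
compound 2 `CCCN(CCC)c1c(C)nc2c(OCc3ccccc3)cccn12`, 0%

Both were tested in a functional assay on the whole organism with Canis familiaris (Canis lupus familiaris) as the target, at a dose of 5 mg/kg by the intravenous route; on this read-out lower numbers stand for a weaker effect and higher numbers for a stronger effect at the one dose given. Compound 1 gives 0% and compound 2 gives 0%, so compound 2 stands level with compound 1: the step of no change at the digits printed from compound 1 to compound 2 (within the scatter). That step swapped one group on the shared core for another without any visible effect in this assay.

Compound 3 `COc1c(C)nc2c(OCc3ccccc3)cccn12` is not yet measured. It differs from compound 2 by methoxy in place of dipropylamino on an aromatic carbon. For the measured compounds named here, the only measured step touches the same place, and it moved nothing beyond the scatter; no other pair in this set speaks to this change. The expectation is therefore that compound 3 will show no shift beyond the scatter, with the step of no change at the digits printed from compound 2 to compound 3 (within the scatter) estimated. Compound 3 is estimated at 0% in this assay, expected to lie between 0% and 12%.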

Compound 3, a percentage reported as inhibition, in the whole organism at one dose (the size of the read-out at that dose, not a potency): 37%
Compound 3: the middle estimate sits 37 percentage points below what was measured; the whole stated range lies below it.
By their numbers in this assay, from the lowest: compounds 1 and 2 (each within the scatter of the next); then compound 3.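

In this assay the switch to methoxy gives a number 37 percentage points higher from compound 2 to compound 3 (beyond the scatter) and, measured against the benzylamino compound, a number 37 percentage points higher from compound 1 to compound 3 (beyond the scatter) at this carbon of the five-membered aromatic ring. The earlier step between the two amino groups showed no movement, but that did not mean the position is indifferent: the group placed here can decide whether any effect appears at this dose. No available measurement explains the rise.

Methoxy changes both the linking atom, oxygen for nitrogen, and the number of heavy atoms, so these compounds cannot show which of the two matters. A dimethylamino group would keep the nitrogen link with a small group, while an ethoxy or longer alkoxy chain would keep the oxygen link and add length.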